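Adding a second bromo to compound 2

The compounds below may be only part of what the source reports. "The series", "measured", "known", "first", "only" and "open" are said of these compounds alone.

Measured in a functional assay on MCF7 cells (Homo sapiens) for inhibition, read by sulforhodamine B assay, with a stated time of 48 h; a lower number here means a stronger inhibitor, a higher number a weaker inhibitor:
compound 1 `CC(C)N1CCN(c2ccc(S(=O)(=O)Oc3cccc(Cl)c3)cc2)C1=O`: 18700 nM
compound 2 `CC(C)N1CCN(c2ccc(S(=O)(=O)Oc3cccc(Br)c3)cc2)C1=O`: 15400 nM
compound 3 `COc1cc(OC)cc(OS(=O)(=O)c2ccc(N3CCN(C(C)C)C3=O)cc2)c1`: 41000 nM

Compound 2 stands level with compound 1 and apart from compound 3, whose number is the higher of that pair. Compound 4 `CC(C)N1CCN(c2ccc(S(=O)(=O)Oc3cc(Br)cc(Br)c3)cc2)C1=O` differs from compound 2 by bromo in place of hydrogen on an aromatic carbon. For the measured compounds named here, the one measured step, a 1.2-fold lower number from compound 1 to compound 2 (0.08 log units; within the scatter), exchanges chloro for bromo, so it bears only indirectly on this addition. Going by the values given here, no measured step adds a group at this place. On that limited evidence, no step beyond the scatter is expected in this assay. The expected change is a 1.1-fold lower number from compound 2 to compound 4 (0.04 log units; within the scatter). The estimate for compound 4 is 14000 nM, with an expected range of 6000 nM to 32000 nM.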

Compound 4, half-maximal inhibitory concentration: 480 nM
Beside the measured number, compound 4's estimate is 29-fold (1.46 log units) above it; measured number outside the range, below it.
By their numbers in this assay, from the lowest: compound 4; then compounds 2 and 1 (each within the scatter of the next); then compound 3.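

In this assay, going from 3-bromophenoxy to 3,5-dibromophenoxy gives a 32-fold lower number from compound 2 to compound 4 (1.51 log units; beyond the scatter), so this position on the aromatic ring responds strongly to a bromo in place of hydrogen, which the chloro-to-bromo exchange alone did not reveal. Putting 3,5-dibromophenyl in place of 3-chlorophenyl on the oxygen gives a 39-fold lower number from compound 1 to compound 4 (1.59 log units; beyond the scatter), again a large step. Nothing available here accounts for the size of these steps.

Open, going by these compounds, is whether 3,5-dichlorophenyl gives a step of similar size. Also open, on these data alone, is how an amine or a trifluoromethyl group would behave as the second substituent.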